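The source may hold more compounds than are shown below. What is called first, only, known or untested is meant among the compounds shown, and "the series" means these compounds.

Compound 1 `COc1cc(OC)c(-c2coc3cc(OCc4ccc(Br)cc4)ccc3c2=O)cc1OC`: 10000 nM
Compound 2 `COc1cc(OC)c(-c2coc3cc(OCc4ccccc4C(F)(F)F)ccc3c2=O)cc1OC`: > 10000 nM (a limit)
Compound 3 `COc1cc(OC)c(-c2coc3cc(OCc4ccc(C#N)cc4)ccc3c2=O)cc1OC`: 6180 nM

In a functional assay on U-251 cells (Homo sapiens) for antiproliferative activity, read by MTT assay, with a stated time of 24 h (on this read-out lower numbers stand for stronger inhibition and higher numbers for weaker inhibition), compound 3 gives 6180 nM, within the scatter of compound 1 at 10000 nM. Compound 2 gives only a limit, > 10000 nM, so it offers no number for comparison.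

Compound 4 `COc1cc(OC)c(-c2coc3cc(OCc4cccc(F)c4)ccc3c2=O)cc1OC` has 3-fluorophenyl in place of 4-cyanophenyl on a saturated chain carbon bound to an oxygen on an aromatic ring.

Within the data shown here, three measured steps bear on this change, all at the same position or on the same ring. The step of a 1.6-fold lower number from compound 1 to compound 3 (0.21 log units; within the scatter) stays within the scatter. The step of an at least 1.6-fold lower number from compound 2 to compound 3 (0.20 log units; that floor lies within the scatter) has a floor within the scatter, and the step of a number no lower from compound 1 to compound 2 (the limit leaves the size open) has no readable size. None of them shows a change beyond the scatter, so no step beyond the scatter is expected in this assay, and no direction can be called.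

The estimate means a 1.2-fold higher number from compound 3 to compound 4 (0.08 log units; within the scatter), which is expected to remain within the scatter.

Compound 4 is expected at 7500 nM, with an estimated range of 3500 nM to 15000 nM.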

Compound 4, half-maximal inhibitory concentration: 3510 nM
Beside the measured number, compound 4's estimate is 2.1-fold (0.33 log units) above it; the measured number falls inside the stated range.
By their numbers in this assay, from the lowest: compounds 4, 3 and 1 (each within the scatter of the next, the first and the last beyond it).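

Among these compounds, with 3-fluorophenyl in place of 4-bromophenyl, this assay records a 2.8-fold lower number from compound 1 to compound 4 (0.45 log units; beyond the scatter) and so the first measured step beyond the scatter at this place, on a saturated chain carbon bound to an oxygen on an aromatic ring. As far as these compounds go, with 3-fluorophenyl in place of 2-(trifluoromethyl)phenyl the result is an at least 2.8-fold lower number from compound 2 to compound 4 (0.45 log units; beyond the scatter) and its size stays open, since the value of compound 2 is only a limit: the limit of > 10000 nM in this assay, at which 1 of the 4 values shown sits. The change from 4-cyanophenyl to 3-fluorophenyl gives a 1.8-fold lower number from compound 3 to compound 4 (0.25 log units; within the scatter) and so sets no order between these two compounds.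

The step from 4-bromophenyl to 3-fluorophenyl changes both the halogen and its place on the ring, and the compounds shown do not separate the two. Also open, from the compounds shown here alone, is how an amine or a carboxylic acid on this ring, or a longer chain in place of the benzyl carbon, would read.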